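The compounds below may be only part of what the source reports. "The series", "measured", "known", "first", "only" and "open" are said of these compounds alone.

Measured compounds and their values in a functional assay on the whole organism (strain KunMing) with Mus musculus as the target, in the maximal electroshock model, with a stated time of 4 h; on this read-out higher numbers stand for an effect only at larger amounts of compound and lower numbers for an effect already at smaller amounts:

Compound 1 `O=C1CCc2cc(-n3cnnc3)ccc2N1Cc1ccccc1F` gives 300 mg/kg.
Compound 2 `O=C1CCc2cc(-n3cnnc3)ccc2N1Cc1cccc(Cl)c1` gives 300 mg/kg.

Compound 2 stands level with compound 1 at the digits shown, and the only measured step, no change at the digits printed from compound 1 to compound 2 (within the scatter), shows that changing the aryl group on the saturated chain carbon bound to the amide-type nitrogen in the ring left the dose unchanged within the scatter. The next compound, compound 3 `O=C1CCc2cc(-n3cnnc3)ccc2N1Cc1cccc(C(F)(F)F)c1`, keeps the shared core and the same attachment point but carries a different group on the aromatic ring: trifluoromethyl in place of chloro on an aromatic carbon.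

Within the data shown here, only the step from compound 1 to compound 2 bears on this change, and it was flat. It is not a direct precedent for swapping chloro for trifluoromethyl, but it does suggest that this part of the molecule tolerates variation without moving the dose. Compound 3 is therefore expected to show no change at the digits printed from compound 2 to compound 3 (within the scatter), that is, no step beyond the scatter. The estimate for compound 3 in this assay is 300 mg/kg, with a range from 150 mg/kg to 600 mg/kg.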

Compound 3, minimum effective dose: 300 mg/kg
Compound 3: the middle estimate sits on the measured number at the digits printed; measured number inside the range.
By their numbers in this assay, from the lowest: compounds 1, 2 and 3 (each within the scatter of the next).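

In this assay the exchange of chloro for trifluoromethyl shows no change at the digits printed from compound 2 to compound 3 (within the scatter) in the minimum effective dose. The earlier step changed both the halogen and where it sat on the aromatic ring, whereas this one keeps the place fixed, on an aromatic carbon meta to a large group, and changes only the group, so the comparison at this position is a direct one. Going from 1 heavy atom to 4 heavy atoms here therefore leaves the dose within the scatter, and nothing measured alongside these values offers an explanation for this level result.

On these data alone, all three compounds carry a group containing fluorine or chlorine on this aromatic ring, so it remains open whether an amine, a carboxylic acid or a methoxy group at the same place would also leave the dose level. As far as these compounds go, it also remains open whether any change in this part of the molecule can move the dose at all, for example a longer chain in place of the single carbon that joins this aromatic ring to the ring nitrogen of the shared core.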